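Swapping the Aryl Tail for a Pentyl Chain

The source may hold more compounds than are shown below. What is called first, only, known or untested is meant among the compounds shown, and "the series" means these compounds.

The series shares a piperidine-bearing core with an ether on its saturated carbon. Compound 1 `COc1ccc(CCCN2CCC(CO)CC2)cc1` gives > 20000 nM in a functional assay on cells (T-cell line, Homo sapiens) for inhibition (on this read-out higher numbers stand for weaker inhibition and lower numbers for stronger inhibition), which is a limit of the assay rather than a number (the limit of > 20000 nM in this assay, at which 1 of the 3 values shown sits). For the measured compounds named here, compound 2 `COc1ccc(CCCN2CCC(COCC3CCCCC3)CC2)cc1` gives 3000 nM in this assay, and the step of an at least 6.6-fold lower number from compound 1 to compound 2 (0.82 log units; beyond the scatter) is the only single-point change measured so far. Compound 3 `COc1cccc(CCCN2CCC(COC(c3ccccc3)c3ccccc3)CC2)c1` gives 1500 nM in this assay; this value and that of compound 2 lie within the scatter of each other, so no order between them is claimed.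

Compound 4 `CCCCCCCCN1CCC(COC(c2ccccc2)c2ccccc2)CC1` differs from compound 3 as follows: pentyl in place of 3-methoxyphenyl on a saturated chain carbon, three bonds along the chain from an amine nitrogen in a ring. Going by the values given here, the one measured step concerns the substituent on the oxygen, not the chain end, so no measured step bears directly on this change. With no evidence pointing either way, a step close to none beyond the scatter is expected. Compound 4 is expected to give 2500 nM in this assay, with a range from 800 nM to 8000 nM. This estimate means an expected step of a 1.7-fold higher number from compound 3 to compound 4 (0.22 log units; within the scatter).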

Compound 4, half-maximal inhibitory concentration: 700 nM
Compound 4: the middle estimate sits 3.6-fold (0.55 log units) above what was measured; measured number below the stated range.
By their numbers in this assay, from the lowest: compound 4; then compounds 3 and 2 (each within the scatter of the next). At a limit, above all of these: compound 1.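

The step of a 2.1-fold lower number from compound 3 to compound 4 (0.33 log units; beyond the scatter) in this assay is the only one measured at this end of the molecule, on a saturated chain carbon, three bonds along the chain from an amine nitrogen in a ring. It shows that the 3-methoxyphenyl group is not needed here for this level of inhibition: pentyl, with no ring and no hydrogen-bond acceptor, gives the lower number. Nothing given here accounts for this modest step.

This single step removes the ring and the methoxy oxygen together, so it cannot tell what each contributes. Also open, as far as these compounds go, are whether a longer chain, or an amine or a carboxylic acid at the chain end, would hold this number, and whether pentyl acts alike with the ether of compound 2.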